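Sulfonamide aryl variation in the benzylamide series

The source may hold more compounds than are shown below. What is called first, only, known or untested is meant among the compounds shown, and "the series" means these compounds.

Measured so far:
compound 1, `O=C(NCc1ccc(CNS(=O)(=O)c2cccc(Cl)c2)cc1)c1ccc(F)cc1`: 1 nM
compound 2, `Cc1ccccc1S(=O)(=O)NCc1ccc(CNC(=O)c2ccc(F)cc2)cc1`: 100 nM
compound 3, `O=C(NCc1ccc(CNS(=O)(=O)c2cccc(F)c2)cc1)c1ccc(F)cc1`: 1000 nM

In an assay on MDA-MB-231 cells for binding affinity to C-X-C chemokine receptor type 4 (Homo sapiens), read by fluorescence and microscopy, with stated times of 10 min and 30 min (a higher number here means that more compound is needed for the effect, a lower number that less compound is needed), compound 1 gives 1 nM, compound 2 gives 100 nM and compound 3 gives 1000 nM. Compound 3 therefore stands at the highest number of the three: its nearest neighbour is compound 2 at 100 nM, its furthest compound 1 at 1 nM, both gaps beyond the scatter.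

Compound 4, `O=C(NCc1ccc(CNS(=O)(=O)c2ccccc2Cl)cc1)c1ccc(F)cc1`, has not yet been measured. It differs from compound 3 in one place: 2-chlorophenyl in place of 3-fluorophenyl on a sulfonyl sulfur

Going by the values given here, two measured steps bear on this change. The step of a 1000-fold higher number from compound 1 to compound 3 (3.00 log units; beyond the scatter) shows that exchanging the halogen on the sulfonyl aryl ring moves the number a long way, with the chlorine-bearing ring at the lower number. The step of a 100-fold higher number from compound 1 to compound 2 (2.00 log units; beyond the scatter) shows that a 2-substituted ring in place of the 3-chlorophenyl ring also raises the number, though less far. Compound 4 combines the chlorine of compound 1 with the 2-position of compound 2, so a lower number than compound 3 is expected, probably landing between compound 1 and compound 2; the expected step in this assay is a 33-fold lower number from compound 3 to compound 4 (1.52 log units; beyond the scatter). Compound 4 is thus estimated at 30 nM, within a range of 3 nM to 300 nM.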

Compound 4, effective concentration (reported as EC, without a stated level of effect): 1000 nM
Beside the measured number, compound 4's estimate is 33-fold (1.52 log units) below it, outside the stated range (above it).
By their numbers in this assay, from the lowest: compound 1; then compound 2; then compounds 3 and 4 (each within the scatter of the next).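

In this assay, the step to the 2-chlorophenyl group in place of the 3-chlorophenyl group on a sulfonyl sulfur is a 1000-fold higher number from compound 1 to compound 4 (3.00 log units; beyond the scatter), so the presence of a chloro group on this ring does not by itself keep the number low; where it stands on the ring matters in this pair. Two further comparisons sharpen this: chloro in place of methyl on an aromatic carbon gives a 10-fold higher number from compound 2 to compound 4 (1.00 log units; beyond the scatter), so the 2-methylphenyl group keeps the lower number of this pair, while 2-chlorophenyl in place of 3-fluorophenyl gives no change at the digits printed from compound 3 to compound 4 (within the scatter), which leaves these two groups indistinguishable here. Nothing in the available data accounts for any of these steps.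

The compounds shown leave open whether the low number of compound 1 is peculiar to chloro or extends to other groups on the sulfonyl aryl ring, such as a bromo, methoxy or nitrile group. Also open, from the compounds shown here alone, is whether a second chloro group on the same ring would keep or lose that number.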